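Methyl on the ring amine of compound 2: expected shift

The source may hold more compounds than are shown below. What is called first, only, known or untested is meant among the compounds shown, and "the series" means these compounds.

Measured compounds:
compound 1 `CN1C[C@H]2C=C(c3cccnc3)C[C@H](C2)C1` — 534 nM
compound 2 `C1=C(c2cccnc2)C[C@@H]2CNC[C@H]1C2` — 23 nM

In an in vitro assay on SH-SY5Y cells for displacement of a labelled ligand from Neuronal acetylcholine receptor; alpha3/beta4 (Homo sapiens) (a higher number here means a weaker inhibitor, a lower number a stronger inhibitor), compound 2 gives the lower of the two numbers; compound 1 gives the higher one, and that gap lies beyond the scatter. Compound 3 `CN1C[C@@H]2C=C(c3cccnc3)C[C@@H](C2)C1` is not yet measured. It differs from compound 2 by methyl in place of hydrogen on an amine nitrogen in a ring. Within the data shown here, no single-change step is available, but the two values shown point toward a weaker number once the methyl is present. Compound 3 is therefore expected to give 150 nM in this assay, within 40 nM to 600 nM, the expected step from compound 2 to compound 3 being a 6.5-fold higher number from compound 2 to compound 3 (0.81 log units; beyond the scatter).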

Compound 3, inhibition constant: 1800 nM
The estimate for compound 3 lay 12-fold (1.08 log units) below the measured number, outside the stated range (above it).
By their numbers in this assay, from the lowest: compound 2; then compound 1; then compound 3.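

In this assay, among these compounds, the amine nitrogen in the ring proves sensitive: methyl in place of hydrogen there gives a 78-fold higher number from compound 2 to compound 3 (1.89 log units; beyond the scatter), a large step and the first single-change reading at this position. Configuration also matters among the methylated compounds, though the step is modest, with a 3.4-fold higher number from compound 1 to compound 3 (0.53 log units; beyond the scatter). This comparison isolates configuration alone: the fact that compounds 1 and 3 differ only in the configuration as drawn

Going by these compounds, whether the compounds with hydrogen on this nitrogen depend on configuration in the same way remains open. So does how an ethyl or a longer chain on this nitrogen would read.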